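A few compounds are considered here, and "the series" means these few. Any claim that something is new, unique, unknown or untested is made for them only; others in the source may bear on it.

Three compounds share one core: compound 1 `O=C(NC1CC1)N1CCC(c2cnccc2-c2ccccc2)CC1`, compound 2 `O=C(NC1CC1)C1CCN(c2cnccc2-c2ccccn2)CC1` and compound 3 `CN(C)C(=O)C1CCN(c2cnccc2-c2ccccn2)CC1`. In an assay on HEK293F cells for inhibition of cholesterol 24-hydroxylase (Homo sapiens), read by trypan blue exclusion, with stated times of 15 min and 5 h (a lower number here means a stronger inhibitor, a higher number a weaker inhibitor), compound 1 gives 950 nM, compound 2 gives 160 nM and compound 3 gives 68 nM. Compound 3 therefore stands lowest of the three numbers, with compound 2 nearest and compound 1 furthest, both beyond the scatter. Among the compounds with values here, the only step between two measured compounds that differ in a single place is a 2.4-fold lower number from compound 2 to compound 3 (0.37 log units; beyond the scatter), and it concerns the group on the carbonyl carbon. Compound 4 `CN(C)C(=O)C1CCN(c2cnccc2-n2cc(C3CC3)cn2)CC1` alters a different part of the molecule: 4-cyclopropyl-1H-pyrazol-1-yl in place of pyridin-2-yl on an aromatic carbon. Within the data shown here, no measured step touches this position, since compound 1 and compound 2 differ in more than one place, so nothing among the measured compounds bears directly on the change. The expectation rests on compound 3 alone, and the expected step, a 1.2-fold higher number from compound 3 to compound 4 (0.07 log units; within the scatter), is accordingly none beyond the scatter. In this assay compound 4 is estimated at 80 nM, within a range from 25 nM to 300 nM.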

Compound 4, half-maximal inhibitory concentration: 12 nM
The estimate for compound 4 lay 6.7-fold (0.82 log units) above the measured number; the whole stated range lies above it.
By their numbers in this assay, from the lowest: compound 4; then compound 3; then compound 2; then compound 1.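

In this assay, within the data shown here, this is the first measured step at the aromatic carbon opposite the ring nitrogen, ortho to a large group: with the dimethylamino carbonyl group held constant, 4-cyclopropyl-1H-pyrazol-1-yl in place of pyridin-2-yl gives a 5.7-fold lower number from compound 3 to compound 4 (0.75 log units; beyond the scatter). The earlier compounds shown here showed a single-place change only on the carbonyl carbon, whereas this result shows that pyridin-2-yl can be replaced here without loss in this assay, and with a step beyond the scatter. Nothing available accounts for this step.

The compounds shown leave open whether the lower number belongs to the pyrazole ring or to its cyclopropyl group; an unsubstituted pyrazol-1-yl, or a pyrazol-1-yl bearing methyl or isopropyl, would separate the two. As far as these compounds go, it also remains open whether the same replacement would hold with the cyclopropylamino carbonyl group of compound 2.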